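This account rests on a few compounds, and the source may have more. Where it says the series, first, only, none or still open, it means among the compounds named here.

Working notes on a small series read in a functional assay on A549 cells (Homo sapiens) for cytotoxicity, read by MTT assay, with a stated time of 48 h; on this read-out higher numbers stand for weaker inhibition and lower numbers for stronger inhibition. Compound 1 `COc1ccc(-c2c[nH]c(=O)n2-c2cc(OC)c(OC)c(OC)c2)cc1` gives > 50000 nM, which is a limit of the assay and not a number. Compound 2 `COc1ccc(-c2cn(C(=O)Nc3cc(OC)c(OC)c(OC)c3)c(=O)n2-c2cc(OC)c(OC)c(OC)c2)cc1N` gives 11100 nM. Compound 3 `COc1cc(-n2c(-c3ccc(Br)cc3)cn(C(C)=O)c2=O)cc(OC)c1OC` gives 1300 nM, the lower of the two actual numbers, and its gap to compound 2 lies beyond the scatter.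

The next compound is compound 4 `COc1ccc(-c2cn(C(C)=O)c(=O)n2-c2cc(OC)c(OC)c(OC)c2)cc1`. It carries methoxy in place of bromo on an aromatic carbon, para to a large group, so that 4-bromophenyl becomes 4-methoxyphenyl: methoxy in place of bromo on an aromatic carbon.

Going by the values given here, no measured pair isolates this change. The expectation therefore rests on compound 3 at 1300 nM. In this assay the expected step is small, toward a higher number and within the scatter: a 1.7-fold higher number from compound 3 to compound 4 (0.23 log units; within the scatter). In this assay the estimated value for compound 4 is 2200 nM, with an expected range of 550 nM to 11000 nM.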

Compound 4, half-maximal inhibitory concentration: 17800 nM
Compound 4: the middle estimate sits 8.1-fold (0.91 log units) below what was measured; measured number above the stated range.
By their numbers in this assay, from the lowest: compound 3; then compounds 2 and 4 (each within the scatter of the next). At a limit, above all of these: compound 1.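

In this assay, the aromatic carbon para to a large group proves sensitive to the group it carries, and the change from 4-bromophenyl to 4-methoxyphenyl is not a neutral swap: a 14-fold higher number from compound 3 to compound 4 (1.14 log units; beyond the scatter). With 4-methoxyphenyl held constant, acetyl on the aromatic nitrogen also counts: an at least 2.8-fold lower number from compound 1 to compound 4 (0.44 log units; beyond the scatter). Compound 1 stands at a limit of the assay and not at a number, so that second step has only a bound on its size: the limit of > 50000 nM in this assay, at which 1 of the 4 values shown sits.

Only bromo and methoxy are shown on this aromatic carbon, so it stays open how chloro, methyl or an amine would read there. On these data alone, it also stays open whether a longer acyl chain such as propanoyl could replace acetyl, and whether the acetyl step holds with 4-bromophenyl.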